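A few compounds are considered here, and "the series" means these few. Any claim that something is new, unique, unknown or untested is made for them only; others in the source may bear on it.

Series measured so far in a functional assay on DU-145 cells (Homo sapiens) for inhibition, read by trypan blue exclusion, with a stated time of 96 h; on this read-out lower numbers stand for stronger inhibition of growth and higher numbers for weaker inhibition of growth:
- compound 1 `COc1ccc(/C=C(/SCc2ccc(Cl)cc2)C(=O)c2ccc(Br)cc2)cc1`: 10000 nM
- compound 2 `O=C(/C(=C\c1ccc(Cl)cc1)SCc1ccc(Cl)cc1)c1ccc(Br)cc1`: 10000 nM
- compound 3 `O=C(/C(=C\c1cc(Cl)cc(Cl)c1Cl)SCc1ccc(Cl)cc1)c1ccc(Br)cc1`: 1000 nM

Compound 3 stands lowest of the three at 1000 nM. The next structure is compound 4 `Cc1ccsc1/C=C(/SCc1ccc(Cl)cc1)C(=O)c1ccc(Br)cc1`, with the change 3-methylthiophen-2-yl in place of 2,3,5-trichlorophenyl on a double-bonded chain carbon bound to a double-bonded chain carbon.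

Two measured steps at this same place bear on it: a 10-fold lower number from compound 1 to compound 3 (1.00 log units; beyond the scatter) and a 10-fold lower number from compound 2 to compound 3 (1.00 log units; beyond the scatter). Both end at the 2,3,5-trichlorophenyl group, and the chloro for methoxy swap between the other two gives no change at the digits printed from compound 1 to compound 2 (within the scatter). Going by the values given here, no measured compound yet carries 3-methylthiophen-2-yl, so the size of the step remains uncertain. Losing the 2,3,5-trichlorophenyl group is expected to move the number upward in this assay, toward the other two values, and the expected step is a 3.0-fold higher number from compound 3 to compound 4 (0.48 log units; beyond the scatter). For compound 4 the estimated value is 3000 nM, with an expected range of 800 nM to 10000 nM.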

Compound 4, concentration for 50% growth inhibition: 25000 nM
Beside the measured number, compound 4's estimate is 8.3-fold (0.92 log units) below it, and the stated range ends below it.
By their numbers in this assay, from the lowest: compound 3; then compounds 1 and 2 (each within the scatter of the next); then compound 4.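

In this assay, the group on the double-bonded chain carbon can move the number in both directions from the level shared by 4-chlorophenyl and 4-methoxyphenyl. Replacing 2,3,5-trichlorophenyl with 3-methylthiophen-2-yl gives a 25-fold higher number from compound 3 to compound 4 (1.40 log units; beyond the scatter), and the same group also falls short of the two simpler phenyl groups, with a 2.5-fold higher number from compound 2 to compound 4 (0.40 log units; beyond the scatter) and a 2.5-fold higher number from compound 1 to compound 4 (0.40 log units; beyond the scatter). Compound 4 therefore marks a weaker end of the series, and nothing measured here accounts for the shift.

Going by these compounds alone, with only one five-membered ring in the set, the contributions of the thiophene ring and its methyl group cannot be separated. Also open, as far as these compounds go, is how a phenyl ring carrying an amine or a carboxylic acid at this place would compare with compound 3.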